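Amide nitrogen substituent: from compound 3 to compound 4

A few compounds are considered here, and "the series" means these few. Any claim that something is new, unique, unknown or untested is made for them only; others in the source may bear on it.

Among the compounds with values here, compound 3 `O=C(NCc1ccncc1)c1c(O)c2cccnc2n(-c2ccccc2)c1=O` stands lowest of the three numbers so far. In a functional assay on the whole organism for inhibition, with Rattus norvegicus as the target, read by cytopathic effect and paw edema, at a dose of 100 mg/kg by the oral route (on this read-out higher numbers stand for more inhibition at the one dose given (going by the name of the read-out) and lower numbers for less inhibition), compound 3 gives 15.4%. Compound 1 `O=C(Nc1cccnc1)c1c(O)c2cccnc2n(-c2ccccc2)c1=O` gives 30.8% in this assay, and compound 2 `O=C(Nc1ccncc1)c1c(O)c2cccnc2n(-c2ccccc2)c1=O` gives 24.3%. The nearest to compound 3 is compound 2, since a number 8.9 percentage points lower from compound 2 to compound 3 (within the scatter); the furthest is compound 1, since a number 15.4 percentage points lower from compound 1 to compound 3 (beyond the scatter). Between the two direct pyridinyl amides, a number 6.5 percentage points lower from compound 1 to compound 2 (within the scatter).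

Compound 4 `Cc1cnccc1NC(=O)c1c(O)c2cccnc2n(-c2ccccc2)c1=O` differs from compound 3 by 3-methylpyridin-4-yl in place of (pyridin-4-yl)methyl on an amide-type nitrogen. The change puts a pyridinyl ring directly on the amide nitrogen, as in compound 2, and carries a methyl on that ring. The measured step that bears on it most is the one it largely reverses: a number 8.9 percentage points lower from compound 2 to compound 3 (within the scatter). The other step toward compound 3, a number 15.4 percentage points lower from compound 1 to compound 3 (beyond the scatter), points the same way, both direct aryl amides lying above compound 3. Within the data shown here, no measured pair shows what the methyl on the ring does, so that part of the change is untested and widens the range. The expected step is upward, a number 8.6 percentage points higher from compound 3 to compound 4 (within the scatter), back toward the level of compound 2 rather than beyond it. Compound 4 is estimated at 24%, between 12% and 36%.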

Compound 4, a percentage reported as inhibition, in the whole organism at one dose (the size of the read-out at that dose, not a potency): 8.8%
Estimate against measurement, compound 4: 15.2 percentage points above; the whole stated range lies above it.
By their numbers in this assay, from the lowest: compounds 4, 3, 2 and 1 (each within the scatter of the next, the first and the last beyond it).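

The methyl now has a measured pair of its own, and on the pyridin-4-yl amide methyl in place of hydrogen on an aromatic carbon goes against inhibition at the one dose given: a number 15.5 percentage points lower from compound 2 to compound 4 (beyond the scatter). Within the data shown here, a pyridinyl ring directly on the amide-type nitrogen therefore does not by itself keep a number at the level of the direct amides, since 3-methylpyridin-4-yl cannot be told apart from (pyridin-4-yl)methyl in this assay, the step being a number 6.6 percentage points lower from compound 3 to compound 4 (within the scatter), while the distance from the pyridin-3-yl amide is the largest so far, a number 22 percentage points lower from compound 1 to compound 4 (beyond the scatter). Nothing at hand bears on what lies behind the step from hydrogen to methyl.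

As far as these compounds go, whether this step belongs to methyl alone, or would also follow from a chlorine, a methoxy group or an amine in the same place on the pyridin-4-yl ring, stays open. Also open, from the compounds shown here alone, is whether a methyl on the pyridin-3-yl ring of the amide, the substituent of compound 1, would give a step of similar size.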